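The compounds below may be only part of what the source reports. "The series", "measured", "known", "first", "only" and "open" are said of these compounds alone.

Working notes on the series.

Compound 1 `CCNCC(=O)Nc1cc(OC)ccc1C(=O)c1ccc(OC)c2c1OC(C)(C)C=C2` carries a chromene-type core with an amide side chain; compound 2 `COc1ccc(C(=O)c2ccc(OC)c3c2OC(C)(C)C=C3)c(NC(=O)CN(C)C)c1` keeps the same core and differs from compound 1 by dimethylamino in place of ethylamino on a saturated chain carbon bound to a carbonyl carbon. Compound 3 `CCNCC(=O)Nc1cc(OC)ccc1C(=O)c1cc(OC)c(OC)c(OC)c1` carries a different core, and compound 4 `COc1ccc(C(=O)c2cc(OC)c(OC)c(OC)c2)c(NC(=O)CN(C)C)c1` is the not yet measured partner of compound 3 carrying the same side chain as compound 2.

In a functional assay on HCT-8 cells (Homo sapiens) for antiproliferative activity, read by MTT assay, with a stated time of 48 h (on this read-out higher numbers stand for weaker inhibition and lower numbers for stronger inhibition), compound 1 gives 3690 nM. In this assay, among the compounds with values here, compound 2 gives 1590 nM, and the step of a 2.3-fold lower number from compound 1 to compound 2 (0.37 log units; beyond the scatter) is the only measured example of this change. In this assay compound 3 gives 1560 nM; this number and that of compound 2 lie within the scatter of each other, so nothing separates them, while against compound 1 compound 3 stands beyond the scatter. The difference between the core of compound 1 and the core of compound 3 is not broken down here.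

Compound 4 differs from compound 3 by dimethylamino in place of ethylamino on a saturated chain carbon bound to a carbonyl carbon, the same change as from compound 1 to compound 2, made at the same place. With a single precedent on another core, the expected step of a 2.2-fold lower number from compound 3 to compound 4 (0.35 log units; beyond the scatter) is taken to be of the same size as the measured step of a 2.3-fold lower number from compound 1 to compound 2 (0.37 log units; beyond the scatter), with wide margins because the carry-over of the step from one core to another rests on compound 1 and compound 2 alone. On that basis compound 4 is estimated at 700 nM in this assay, expected to fall between 350 nM and 1600 nM.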

Compound 4, half-maximal inhibitory concentration: 790 nM
For compound 4 the middle estimate is 1.1-fold (0.05 log units) below the measured one; low and high end bracket the measured number.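

In this assay, the step of a 2.0-fold lower number from compound 3 to compound 4 (0.30 log units; within the scatter) is a second example of dimethylamino in place of ethylamino on a saturated chain carbon bound to a carbonyl carbon; taken alone, it does not separate the two compounds. Set beside the earlier example, the change carries over from the core of compound 1 to the core of compound 3 with no difference in size that can be told from the scatter: the same change on two cores in this assay, a 2.3-fold lower number (0.37 log units; beyond the scatter) from compound 1 to compound 2 and a 2.0-fold lower number (0.30 log units; within the scatter) from compound 3 to compound 4, 1.2-fold (0.07 log units) apart, within the scatter of two such steps This agreement rests on one pair of compounds per core in a single assay, and one of the two steps lies within the scatter, so it supports a transfer between these two cores only, gives no general rule for the series and does not show what lies behind the step.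

Open, on these data alone, is how a primary amine or a diethylamino group would compare with ethylamino and dimethylamino at the same place on either core. Also open, as far as these compounds go, is whether a longer chain between the carbonyl carbon and the amine would leave the step at the size seen on these two cores, and whether the step would hold on any further core.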